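Replacing the fused heterocycle of an electrophilic ketone inhibitor

This account rests on a few compounds, and the source may have more. Where it says the series, first, only, none or still open, it means among the compounds named here.

Measured so far:
compound 1 `CCCCCCCC/C=C\CCCCCCC(=O)c1nc2ncccc2o1` — 2.3 nM
compound 2 `O=C(CCCCCCc1ccccc1)c1nnn[nH]1` — > 1000 nM
compound 3 `CCCCCCCC/C=C\CCCCCCC(=O)c1ncc(-c2ccco2)o1` — 54 nM

The three compounds above were tested in an assay on isolated protein for inhibition of Fatty-acid amide hydrolase 1 (Homo sapiens); on this read-out higher numbers stand for weaker inhibition and lower numbers for stronger inhibition. Compound 1 gives the lowest of the two numbers shown; the nearest is compound 3, whose number is higher by a margin beyond the scatter. Compound 2 gives only a limit of the assay, not a number, in this assay (the limit of > 1000 nM in this assay, at which 1 of the 3 values shown sits).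

The piece follows the step from compound 1 to compound 4 `CCCCCCCC/C=C\CCCCCCC(=O)c1nccn1C`, which has not yet been measured. The change lies at the carbonyl carbon: a group of 6 heavy atoms (4 carbon, 2 nitrogen; one five-membered aromatic ring with 2 hetero atoms) in place of a group of 9 heavy atoms (6 carbon, 2 nitrogen, 1 oxygen; one five-membered aromatic ring with 2 hetero atoms, one six-membered aromatic ring with 1 hetero atom), on a carbonyl carbon. The smaller five-membered ring with two hetero atoms takes the place of the fused pair of rings, while the long unsaturated chain and the carbonyl stay as they are.

Among the compounds with values here, no step between measured compounds is available to guide the size of this change. Compound 3, which also keeps the chain and the carbonyl but carries a different five-membered ring, sits well above compound 1, so a loss of potency beyond the scatter is expected here as well. The estimated step from compound 1 to compound 4 is a 220-fold higher number from compound 1 to compound 4 (2.34 log units; beyond the scatter). Compound 4 is expected to give about 500 nM in this assay, within a range from 100 nM to 3000 nM.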

Compound 4, inhibition constant: > 100000 nM
Compound 4 gave a limit, no number (the forecaster's own chance of this, stated with the estimate: 25%); at least 200-fold (2.30 log units) between middle value and limit.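

In this assay compound 4 gives no number, only a limit of the assay: the limit of > 100000 nM in this assay, at which 1 of the 4 values shown sits.

Placing 1-methyl-1H-imidazol-2-yl on the carbonyl carbon in place of the fused pair of rings gives an at least 43000-fold higher number from compound 1 to compound 4 (4.63 log units; beyond the scatter), so the long unsaturated chain and the carbonyl alone are not enough to keep inhibition in this assay. Compound 3 keeps the same chain and carbonyl with another five-membered ring and still gives a measurable 54 nM, which shows that the outcome depends heavily on which ring sits at this position, not merely on a ring being present.

This single step removes the six-membered ring and the oxygen and adds a methyl group, so the compounds shown cannot say which of these changes accounts for the loss. A 1H-imidazol-2-yl group without the methyl, or a plain oxazol-2-yl group, on the same chain and carbonyl would help to pull these changes apart.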